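An Isomeric Aryl Swap on the Amide Nitrogen

This account rests on a few compounds, and the source may have more. Where it says the series, first, only, none or still open, it means among the compounds named here.

Measured compounds:
compound 1 `Cc1cc(C)cc(NC(=O)CN2CCC(c3cccc[n+]3[O-])CC2)c1`: 52 nM
compound 2 `CCOc1cccc(C(=O)NCN2CCC(c3cccc[n+]3[O-])CC2)c1`: 324 nM

Of the compounds shown here, two sharing the same core have been measured in a functional assay on HEK293 cells for agonist activity at D(4) dopamine receptor (Homo sapiens), read by FLIPR; on this read-out lower numbers stand for an effect already at smaller amounts and higher numbers for an effect only at larger amounts of compound. Compound 1 gives 52 nM and compound 2 gives 324 nM; compound 1 carries the lowest number of the two, and the gap to compound 2 lies beyond the usual scatter. Compound 2 differs from compound 1 in more than one place, so what its higher number shows cannot be attributed to any single change.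

The next compound, compound 3 `CCc1cccc(NC(=O)CN2CCC(c3cccc[n+]3[O-])CC2)c1`, changes only the aryl group on the amide nitrogen of compound 1: 3-ethylphenyl in place of 3,5-dimethylphenyl on an amide-type nitrogen. The two have the same atoms, joined differently. For the measured compounds named here, no pair of measured compounds differing in one place is available to calibrate such a change, so the expectation rests on compound 1 alone. For this kind of rearrangement a small step is expected, most likely towards a higher number, though a result within the scatter would not surprise. The expected step is a 1.9-fold higher number from compound 1 to compound 3 (0.28 log units; within the scatter). Compound 3 is estimated at 100 nM, with a range from 30 nM to 350 nM.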

Compound 3, half-maximal effective concentration: 95 nM
Beside the measured number, compound 3's estimate is 1.1-fold (0.02 log units) above it, and the stated range covers the measured number.
By their numbers in this assay, from the lowest: compounds 1 and 3 (each within the scatter of the next); then compound 2.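

With compound 3, the aryl group on the amide nitrogen gains its first comparison that differs in one place only: in this assay, 3-ethylphenyl in place of 3,5-dimethylphenyl gives a 1.8-fold higher number from compound 1 to compound 3 (0.26 log units; within the scatter) and so stays within the usual scatter. The earlier pair could not show this, since compound 1 and compound 2 differ in more than one place; here, two aryl groups made of the same atoms, joined differently, cannot be told apart on this read-out, and agonist activity at a comparable level survives the rearrangement on this amide-type nitrogen. Nothing available explains why these two aryl groups give values within the scatter of each other.

Going by these compounds, both aryl groups compared here carry only carbon substituents, so it remains open how this position would respond to a methoxy group, an amine or a carboxylic acid on the ring, to a longer chain such as propyl, or to an unsubstituted phenyl. It also remains open which of the several differences between compound 1 and compound 2 accounts for the higher number of compound 2, as no single change separating them can be read from the compounds shown.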